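Replacing the Propoxycarbonyl Group of Compound 2

The source may hold more compounds than are shown below. What is called first, only, known or untested is meant among the compounds shown, and "the series" means these compounds.

Two esters built on one shared core have been tested so far in a functional assay on cells (Platelet, Homo sapiens) for inhibition; a lower number here means a stronger inhibitor, a higher number a weaker inhibitor. Compound 1 (`CCOC(=O)c1cccc(-c2nn(Cc3ccccc3)c3ccccc23)c1`) gives > 10000 nM, which is a limit of the assay and not a number. Compound 2 (`CCCOC(=O)c1ccc(-c2nn(Cc3ccccc3)c3ccccc23)cc1`) gives > 10000 nM, which is likewise a limit. For the measured compounds named here, compound 2 therefore offers no exact number to start from, and no measured step between closely matched compounds is available as a guide.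

Compound 3 (`CO/N=C\c1ccc(-c2nn(Cc3ccccc3)c3ccccc23)cc1`) keeps the shared core but carries a different group on an aromatic carbon of a six-membered aromatic ring of carbon only, para to a large group. The change is this: a group of 4 heavy atoms (2 carbon, 1 nitrogen, 1 oxygen; no ring) in place of a group of 6 heavy atoms (4 carbon, 2 oxygen; no ring), on an aromatic carbon. In words, a smaller group takes the place of the propoxycarbonyl group.

With so little to go on, the expectation stays cautious, and compound 3 may also end up reported only as a limit. A small move towards stronger inhibition is expected, an at least 1.2-fold lower number from compound 2 to compound 3 (0.09 log units; that floor lies within the scatter), and it may prove to be no change beyond the scatter. For compound 3 the estimated value in this assay is 8000 nM, with an expected range of 2500 nM to 20000 nM.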

Compound 3, half-maximal inhibitory concentration: > 10000 nM
Compound 3: a limit, no number; the forecaster's own chance of this, stated with the estimate: 60%; at least 1.2-fold (0.09 log units) between middle value and limit.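

Compound 3 gives only a limit, as compound 2 does, so no step can be read between compound 2 and compound 3 because all the results sit at one value: the limit of > 10000 nM in this assay, at which 3 of the 3 values shown sit.

The compounds shown leave open how compound 2 and compound 3 truly compare, and whether any group in that place gives a measurable value in this assay.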